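A few compounds are considered here, and "the series" means these few. Any claim that something is new, unique, unknown or untested is made for them only; others in the source may bear on it.

Measured compounds in the series:

compound 1, `O=C(CCCCCCc1ccccc1)c1ncc(-c2ccccc2F)o1`, 110 nM
compound 2, `NC(=O)c1cccc(-c2cnc(C(=O)CCCCCCc3ccccc3)o2)c1`, 6 nM
compound 3, `NC(=O)c1cccc(-c2cnc(C(=O)CCCCCCc3ccccc3)o2)n1`, 1 nM

All three were run in an assay (Rattus norvegicus) for inhibition of Fatty-acid amide hydrolase 1 (Homo sapiens); a higher number here means a weaker inhibitor, a lower number a stronger inhibitor. Compound 3 gives the lowest number of the three: the nearest is compound 2, with a 6.0-fold lower number from compound 2 to compound 3 (0.78 log units; beyond the scatter), and the furthest is compound 1, with a 110-fold lower number from compound 1 to compound 3 (2.04 log units; beyond the scatter). Compound 1 to compound 2 shows an 18-fold lower number from compound 1 to compound 2 (1.26 log units; beyond the scatter), so the carbamoyl-bearing ring on the shared core accounts for most of the movement seen so far, and the ring nitrogen adds a further modest step.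

Compound 4, `NS(=O)(=O)c1ccc(-c2cnc(C(=O)CCCCCCc3ccccc3)o2)s1`, has not been measured. The change from compound 3 is 5-sulfamoylthiophen-2-yl in place of 6-carbamoylpyridin-2-yl on an aromatic carbon. Among the compounds with values here, none of the measured steps covers a sulfamoyl group or a five-membered ring at this position; the nearest comparisons are the two steps just named, which show that the carbamoyl group and the ring heteroatom each matter. Compound 4 keeps a hydrogen-bond donor and acceptors on the outer ring, but on a different ring and a different group, so some loss against compound 3 is expected rather than a gain.

Compound 4 is estimated at 5 nM, within 1 nM to 30 nM, which is expected to mean a 5.0-fold higher number from compound 3 to compound 4 (0.70 log units; beyond the scatter).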

Compound 4, inhibition constant: 3 nM
The estimate for compound 4 lay 1.7-fold (0.22 log units) above the measured number, within the range that was stated.
By their numbers in this assay, from the lowest: compound 3; then compounds 4 and 2 (each within the scatter of the next); then compound 1.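

At the position next to the ring oxygen of the shared core, a carbamoyl group on a six-membered aromatic ring is not the only substituent that gives a low number in this assay: 5-sulfamoylthiophen-2-yl, a five-membered aromatic ring carrying a different group, brings a 37-fold lower number from compound 1 to compound 4 (1.56 log units; beyond the scatter) when it replaces 2-fluorophenyl. Set against 3-carbamoylphenyl, the change gives a 2.0-fold lower number from compound 2 to compound 4 (0.30 log units; within the scatter) and so does not separate the two groups. Set against 6-carbamoylpyridin-2-yl, it gives a 3.0-fold higher number from compound 3 to compound 4 (0.48 log units; beyond the scatter) and leaves that group with the lowest number of the four.

The last change replaces the ring and the group together, so the compounds shown cannot assign that modest step to either one; 5-carbamoylthiophen-2-yl and 6-sulfamoylpyridin-2-yl would separate the two, and a carboxylic acid or a nitrile on the same thiophene ring would show how much depends on the sulfamoyl group itself. Nothing available here accounts for any of these differences.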